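Swapping the Pyridine Ring for Thiophene on a Shared Core

This account rests on a few compounds, and the source may have more. Where it says the series, first, only, none or still open, it means among the compounds named here.

Compound 3 `O=C(Nc1ccc(-c2ccncc2)cc1)C1CCCN(Cc2ccc(F)c(F)c2)C1` has the lowest of the two numbers recorded in a functional assay on A-375 cells (Homo sapiens) for antiproliferative activity; a higher number here means a weaker inhibitor, a lower number a stronger inhibitor: compound 3 gives 600 nM. Its nearest neighbour is compound 2 `O=C(Nc1ccc(-c2cscn2)cc1)C1CCCN(Cc2cc(F)cc(F)c2)C1`, which in this assay gives 1360 nM, a gap beyond the usual scatter. Compound 1 `O=C(Nc1ccc(-c2cscn2)cc1)C1CCCN(C(=O)c2ccc(F)c(F)c2)C1` in this assay gives only a limit, > 20000 nM. Going by the values given here, the single measured step, an at least 14-fold lower number from compound 1 to compound 2 (1.16 log units; beyond the scatter), concerns the group on the amine nitrogen in the ring, and its size is stated as a floor because of the limit of > 20000 nM in this assay, at which 1 of the 3 values shown sits.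

Compound 4 `O=C(Nc1ccc(-c2ccsc2)cc1)C1CCCN(Cc2ccc(F)c(F)c2)C1` keeps the benzyl group of compound 3 and alters only the aromatic substituent: thiophen-3-yl in place of pyridin-4-yl on an aromatic carbon. Among the compounds with values here, no measured step touches this part of the molecule; compounds 2 and 3 differ both here and in the benzyl group, so their two values cannot separate the two effects. Without a direct precedent, only a modest change is expected, a 1.3-fold higher number from compound 3 to compound 4 (0.12 log units; within the scatter), with no firm direction. Compound 4 is therefore estimated at 800 nM in this assay, with a likely range from 250 nM to 2500 nM.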

Compound 4, half-maximal inhibitory concentration: 950 nM
For compound 4 the middle estimate is 1.2-fold (0.07 log units) below the measured one; the range from low to high includes it.
By their numbers in this assay, from the lowest: compounds 3, 4 and 2 (each within the scatter of the next, the first and the last beyond it). At a limit, above all of these: compound 1.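

In this assay, going by these compounds alone, this is the first measured change at the aromatic substituent, which sits para to a large group on the six-membered aromatic ring of carbon only: a 1.6-fold higher number from compound 3 to compound 4 (0.20 log units; within the scatter). The six-membered pyridin-4-yl, with its ring nitrogen, and the five-membered thiophen-3-yl, with its ring sulfur, therefore cannot be told apart in this assay, so in this pair the ring nitrogen is not needed to keep the activity seen with compound 3. Nothing measured here explains why the two groups give such similar numbers.

From the compounds shown here alone, it remains open whether a plain phenyl ring or a non-aromatic group, such as a carboxylic acid or an amine on a short chain, would fit at this position. Each would show whether an aromatic ring is needed here at all.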